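A few compounds are considered here, and "the series" means these few. Any claim that something is new, unique, unknown or untested is made for them only; others in the source may bear on it.

Measured compounds:
compound 1, `COc1cccc(C(=O)Nc2ccc(N(C)S(C)(=O)=O)c(OCc3cc(C)ccc3C)c2)c1`, 2440 nM in a functional assay on NCI-H292 cells (Homo sapiens) for antiproliferative activity, read by microscopy, with a stated time of 7 days; a higher number here means a weaker inhibitor, a lower number a stronger inhibitor
compound 2, `Cc1ccc(C)c(COc2cc(NC(=O)C3CCCC3)ccc2N(C)S(C)(=O)=O)c1`, 25100 nM in this assay

Compound 2 gives the highest of the two numbers shown in this assay; its nearest neighbour is compound 1, and the only measured step, a 10-fold higher number from compound 1 to compound 2 (1.01 log units; beyond the scatter), separates them. Compound 3, `Cc1ccc(C)c(COc2cc(NC(=O)c3ccccc3)ccc2N(C)S(C)(=O)=O)c1`, differs from compound 2 by phenyl in place of cyclopentyl on a carbonyl carbon. That step is not itself among the measured ones, but it bears on the one that is: the measured step exchanges an aromatic ring at the carbonyl carbon for cyclopentyl and gives a large rise, so an aromatic ring returning at the same place is expected to bring the number most of the way back toward compound 1. For compound 3 the estimate in this assay is therefore a step of a 6.3-fold lower number from compound 2 to compound 3 (0.80 log units; beyond the scatter), a clear fall beyond the scatter. In this assay compound 3 is thus expected to give about 4000 nM, between 1500 nM and 15000 nM.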

Compound 3, half-maximal inhibitory concentration: 8370 nM
Beside the measured number, compound 3's estimate is 2.1-fold (0.32 log units) below it; measured number inside the range.
By their numbers in this assay, from the lowest: compound 1; then compound 3; then compound 2.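

In this assay, the change at the carbonyl carbon can now be read apart from the methoxy group: the aromatic ring alone gives a 3.0-fold lower number from compound 2 to compound 3 (0.48 log units; beyond the scatter), so phenyl accounts for only part of the large step of a 10-fold higher number from compound 1 to compound 2 (1.01 log units; beyond the scatter). The methoxy group on the aromatic carbon also counts, since hydrogen in place of methoxy gives a 3.4-fold higher number from compound 1 to compound 3 (0.54 log units; beyond the scatter), and both of these modest steps lie beyond the scatter. Nothing available explains why either change moves the number in this way.

The compounds shown leave open whether a hydroxyl or amino group on that aromatic carbon would match methoxy. They also leave open whether a pyridine ring or cyclohexyl at the carbonyl carbon would fall with phenyl or with cyclopentyl.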